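The source may report more compounds than this note shows. Statements on the series, on what has been measured and on what is new or still open speak of the compounds shown alone.

Compound 1 `O=C(Nc1cc(-c2ccccn2)n[nH]1)N1CCC(c2ccc(Cl)cc2)CC1` and compound 2 `COc1ccc(C(=O)Nc2cc(-c3ccccn3)n[nH]2)cc1` share one core. In an ADME assay on cells (Peritoneal macrophage cell, Mus musculus) for cytotoxicity, read by fluorescence and resazurin assay, with a stated time of 3 days (on this read-out higher numbers stand for lower toxicity in this test and lower numbers for higher toxicity in this test), compound 1 gives > 55000 nM, a limit of the test rather than a number. In this assay compound 2 gives > 40300 nM, likewise a limit and not a number. Compound 2 therefore stands at the limit of > 40300 nM in this assay, at which 1 of the 2 values shown sits, and nothing measured separates it from compound 1. Compound 3 `O=C(Nc1cc(-c2ccccn2)n[nH]1)c1ccc(Cl)cc1` differs from compound 2 by chloro in place of methoxy on an aromatic carbon. For the measured compounds named here, no step between measured compounds shows what this change does, so no move beyond the scatter of this assay is expected; compound 3 is estimated at 40000 nM, between 15000 nM and 110000 nM. The expected change is a number no higher from compound 2 to compound 3 (the limit leaves the size open).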

Compound 3, half-maximal cytotoxic concentration: > 64000 nM
Compound 3: only a limit was reported; the forecaster's own chance of this, stated with the estimate: 70%; middle value at least 1.6-fold (0.20 log units) away from the limit.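

In this assay compound 3 gives > 64000 nM, again a limit and not a number, so no step can be read between compound 2 and compound 3. As far as these compounds go, what chloro in place of methoxy does to this read-out remains open.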